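Hydroxy for chloro on the aryl ring of compound 1

This account rests on a few compounds, and the source may have more. Where it says the series, first, only, none or still open, it means among the compounds named here.

Compound 1 `Clc1ccc(-c2nc3ccccn3c2NC2CCCCC2)cc1` is the reference point of the series. In an assay on membranes from brain for displacement of a labelled ligand from adenosine receptor A1 (Rattus norvegicus) (a lower number here means a stronger inhibitor, a higher number a weaker inhibitor), compound 1 gives > 100000 nM, which is a limit of the assay and not a number. Compound 2 `Cc1ccc(-c2nc3ccccn3c2NC2CCCCC2)cc1` carries methyl in place of chloro on the aromatic carbon; in this assay compound 2 gives 2060 nM. Compound 3 `O=[N+]([O-])c1ccc(-c2nc3ccccn3c2NC2CCCCC2)cc1` carries nitro in place of chloro on the aromatic carbon; in this assay compound 3 gives > 100000 nM, again a limit and not a number. Two of the three values shown sit at the limit of > 100000 nM in this assay, at which 2 of the 3 values shown sit. The measured steps read: an at least 48-fold lower number from compound 1 to compound 2 (1.68 log units; beyond the scatter); a step that the two limits leave unreadable from compound 1 to compound 3; an at least 48-fold higher number from compound 2 to compound 3 (1.68 log units; beyond the scatter).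

Compound 4 `Oc1ccc(-c2nc3ccccn3c2NC2CCCCC2)cc1` differs from compound 1 by hydroxy in place of chloro on an aromatic carbon. Going by the values given here, the steps that bear on this change are the two exchanges at the same aromatic carbon: methyl brought compound 2 to a readable number, nitro left compound 3 at the limit. Since compound 1 stands at the limit, any readable step in this assay can only be downward. Hydroxy is expected to land between those two outcomes, so the step from compound 1 to compound 4 is expected to be an at least 12-fold lower number from compound 1 to compound 4 (1.09 log units; beyond the scatter). Compound 4 is expected to give about 8000 nM in this assay, within 1000 nM to 100000 nM, with a real chance that only a limit is reported.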

Compound 4, inhibition constant: 5530 nM
Beside the measured number, compound 4's estimate is 1.4-fold (0.16 log units) above it; low and high end bracket the measured number.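

In this assay, hydroxy at this position, para to a large group, is a second exchange that brings the series to a readable number: an at least 18-fold lower number from compound 1 to compound 4 (1.25 log units; beyond the scatter), and an at least 18-fold lower number from compound 3 to compound 4 (1.25 log units; beyond the scatter). Methyl is thus no longer the only group at this aromatic carbon to give a number, although hydroxy does not match it, with a 2.7-fold higher number from compound 2 to compound 4 (0.43 log units; beyond the scatter), a modest step that is still beyond the scatter. Across the four compounds, methyl and hydroxy give readable numbers while chloro and nitro do not, and the two steps out of compounds 1 and 3 are bounds and not sizes, since each starts from a limit of the assay and not from a number: the limit of > 100000 nM in this assay, at which 2 of the 4 values shown sit.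

As far as these compounds go, how far compound 1 and compound 3 actually lie past that limit stays unknown, so the full size of the gain with hydroxy cannot be stated. Also open, from the compounds shown here alone, is whether an amine, a methoxy or a fluoro at the same carbon would fall with methyl and hydroxy or with chloro and nitro, and the four compounds offer no measured property that explains this split.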